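A few compounds are considered here, and "the series" means these few. Any claim that something is new, unique, unknown or untested is made for them only; others in the source may bear on it.

Compound 3 `Cc1ccnc(/C(N)=N/NC(=S)N2CCCCCC2)c1` and compound 1 `N/C(=N\NC(=S)N1CCCCCC1)c1ccccn1` differ in a single place: hydrogen in place of methyl on an aromatic carbon. In a functional assay on A-431 cells (Homo sapiens) for cytotoxicity, read by MTT assay, with a stated time of 72 h (on this read-out lower numbers stand for stronger inhibition and higher numbers for weaker inhibition), compound 3 gives 8000 nM, and compound 1 gives 3000 nM, so the step is a 2.7-fold lower number from compound 3 to compound 1 (0.43 log units; beyond the scatter). Compound 2 `Cc1ccnc(/C(N)=N/NC(=S)N2CCN(c3ccccn3)CC2)c1` is built on a different core, and in this assay compound 2 gives 15500 nM. The difference between the core of compound 2 and the core of compound 3 is not broken down here. Compound 4 `N/C(=N\NC(=S)N1CCN(c2ccccn2)CC1)c1ccccn1` has not yet been measured in this assay. It differs from compound 2 by the same change seen before: hydrogen in place of methyl on an aromatic carbon. Because the earlier example of this change gave a 2.7-fold lower number from compound 3 to compound 1 (0.43 log units; beyond the scatter), a step of about that size is expected from compound 2 to compound 4, namely a 2.6-fold lower number from compound 2 to compound 4 (0.41 log units; beyond the scatter). Compound 4 is therefore estimated at 6000 nM, most likely between 2500 nM and 14000 nM.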

Compound 4, half-maximal inhibitory concentration: 4300 nM
The estimate for compound 4 lay 1.4-fold (0.14 log units) above the measured number; low and high end bracket the measured number.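

Swapping the methyl for hydrogen, which turns 4-methylpyridin-2-yl into pyridin-2-yl, again lowers the number in this assay, with a 3.6-fold lower number from compound 2 to compound 4 (0.56 log units; beyond the scatter). Set beside the earlier example, the step carries over from one core to the other at much the same size: the same change on two cores in this assay, a 2.7-fold lower number (0.43 log units; beyond the scatter) from compound 3 to compound 1 and a 3.6-fold lower number (0.56 log units; beyond the scatter) from compound 2 to compound 4, 1.4-fold (0.13 log units) apart, within the scatter of two such steps. This rests on just two pairs of compounds read in this assay, so it does not show that the step would hold on other cores, and it does not explain why the number falls.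

Only methyl and hydrogen appear on this aromatic carbon. On these data alone, what a larger group there, such as ethyl, methoxy or a chlorine atom, would do remains open.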